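The source may report more compounds than this note shows. Statements on the series, on what has been measured and on what is new or still open speak of the compounds shown alone.

The measured compounds:
Compound 1 `Cc1ccc(-c2c3c(nc(C)c2C(OC(C)(C)C)C(=O)O)CCN(C)C3)cc1` gives in an ADME assay on MT2 cells (Homo sapiens) for cytotoxicity, read by XTT assay, with a stated time of 4 days (on this read-out higher numbers stand for lower toxicity in this test and lower numbers for higher toxicity in this test), only a limit, > 40000 nM.
Compound 2 `CC(=O)N1CCc2nc(C)c(C(OC(C)(C)C)C(=O)O)c(-c3ccc(C)cc3)c2C1` gives in this assay only a limit, > 40000 nM.
Compound 3 `Cc1ccc(-c2c3c(nc(C)c2C(OC(C)(C)C)C(=O)O)CCN(c2cccc(-c4ccccc4)c2)C3)cc1` gives in this assay only a limit, > 40000 nM.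

Within the data shown here, compound 3 thus stands nowhere in particular on these numbers: its own value is a limit, and the two other values shown are limits as well, so no compound can be set above or below another. The three compounds share one core and differ only in the group carried on an amine nitrogen in a ring. The steps among the measured compounds are a step that the two limits leave unreadable from compound 1 to compound 3 and a step that the two limits leave unreadable from compound 2 to compound 3, and likewise a step that the two limits leave unreadable from compound 1 to compound 2; none of them can be read since (the limit of > 40000 nM in this assay, at which 3 of the 3 values shown sit). Compound 4 `COC(=O)N1CCc2nc(C)c(C(OC(C)(C)C)C(=O)O)c(-c3ccc(C)cc3)c2C1` carries the change (methoxycarbonyl in place of 3-phenylphenyl on an amine nitrogen in a ring). Compound 4 is not yet measured. With every shown value sitting at the same limit, no step beyond the scatter is expected in this assay in either direction, only an estimated step that the limit leaves unreadable from compound 3 to compound 4. Compound 4 is expected to give 60000 nM, within 30000 nM to 150000 nM, most likely reported again as a limit.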

Compound 4, half-maximal cytotoxic concentration: > 40000 nM
Compound 4 gave a limit, no number (the forecaster's own chance of this, stated with the estimate: 90%); the middle value is on the limit's open side.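

Among these compounds, compound 4 sits at the same limit as compound 1, compound 2 and compound 3, so no step from any of them to compound 4 can be read: the limit of > 40000 nM in this assay, at which 4 of the 4 values shown sit.

The compounds shown leave open whether the group on the amine nitrogen in a ring makes any difference in this assay.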